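Cyanoguanidines on a shared core: ring size at the imine nitrogen

The compounds below may be only part of what the source reports. "The series", "measured", "known", "first", "only" and "open" are said of these compounds alone.

Measured so far:
compound 1, `CCC(C)/N=C(\NC#N)Nc1cccnc1`, in a functional assay on the whole organism (blood, strain Wistar-Okamoto) with Rattus norvegicus as the target, with a stated time of 5 days (on this read-out lower numbers stand for an effect already at smaller amounts and higher numbers for an effect only at larger amounts of compound), gives 20 mg/kg;
compound 2, `N#CN/C(=N\C1CC1)Nc1cccnc1`, in this assay gives 20 mg/kg.

Compound 2 stands level with compound 1 at the digits shown, and the one step that bears on the next change, no change at the digits printed from compound 1 to compound 2 (within the scatter), lies within the scatter. Compound 3, `N#CN/C(=N\C1CCCCC1)Nc1cccnc1`, differs from compound 2 as follows: cyclohexyl in place of cyclopropyl on a double-bonded nitrogen. Since the step from sec-butyl to cyclopropyl left the minimum effective dose unmoved, a change of step no change at the digits printed from compound 2 to compound 3 (within the scatter) is expected here, none beyond the scatter. Compound 3 is therefore estimated at 20 mg/kg, with a range from 10 mg/kg to 40 mg/kg.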

Compound 3, minimum effective dose: 20 mg/kg
The estimate for compound 3 equals the measured number at the digits printed; the range from low to high includes it.
By their numbers in this assay, from the lowest: compounds 1, 2 and 3 (each within the scatter of the next).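

In this assay, the six-membered ring of cyclohexyl on a double-bonded nitrogen matches the three-membered ring of cyclopropyl (no change at the digits printed from compound 2 to compound 3 (within the scatter)). It also matches the open-chain sec-butyl (no change at the digits printed from compound 1 to compound 3 (within the scatter)). Across these three compounds, then, neither ring size nor the presence of a ring separates the doses at this position, and nothing measured offers an explanation for that. Going by these compounds, whether an amine, a carboxylic acid or a phenyl ring at this place would shift the dose stays open. So does the effect of a longer chain such as n-octyl.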